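Nitrophenyl to Methylfuranyl on the Saturated Ring Carbon

The source may report more compounds than this note shows. Statements on the series, on what has been measured and on what is new or still open speak of the compounds shown alone.

Within the data shown here, compound 3 `N#CC1=C(N)N(c2ccc(S(N)(=O)=O)cc2)C2=C(CCCC2)C1c1ccc([N+](=O)[O-])cc1` stands lowest of the three numbers measured so far in a functional assay on Ehrlich cells (Mus musculus) for cytotoxicity, read by trypan blue exclusion, with a stated time of 2 h, tested at 50 ug/mL; on this read-out higher numbers stand for a stronger effect at the one concentration tested and lower numbers for a weaker effect: in this assay compound 3 gives 10%. Its nearest neighbour is compound 1 `N#CC1=C(N)N(c2ccc(S(N)(=O)=O)cc2)C2=C(CCCC2)C1c1ccccc1`, which in this assay gives 20%, and the step of a number 10 percentage points lower from compound 1 to compound 3 (within the scatter). Furthest away is compound 2 `COc1ccc(C2C(C#N)=C(N)N(c3ccc(S(N)(=O)=O)cc3)C3=C2CCCC3)cc1`, which in this assay gives 100%; the step of a number 90 percentage points lower from compound 2 to compound 3 (beyond the scatter).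

Compound 4 `Cc1ccc(C2C(C#N)=C(N)N(c3ccc(S(N)(=O)=O)cc3)C3=C2CCCC3)o1` differs from compound 3 in one place: 5-methylfuran-2-yl in place of 4-nitrophenyl on a saturated ring carbon. The two measured steps that reach compound 3 both exchange one substituent for another on a six-membered aromatic ring of carbon only; the step from compound 1 to compound 3 is within the scatter, while the step from compound 2 to compound 3 is large. Among the measured compounds shown here, neither step exchanges the whole ring for a five-membered aromatic ring with one hetero atom, so no measured step bears directly on the change to compound 4. The measured numbers span nearly the whole range of this assay, so the expectation for compound 4 is wide. Compound 4 is expected to give 35% in this assay, with a range from 10% to 90%. The expected step is a number 25 percentage points higher from compound 3 to compound 4 (beyond the scatter).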

Compound 4, a percentage reported as activity, at one concentration (the size of the read-out at that concentration, not a potency): 10%
Compound 4: middle estimate off by 25 percentage points, on the high side, and the stated range covers the measured number.
By their numbers in this assay, from the lowest: compounds 3, 4 and 1 (each within the scatter of the next); then compound 2.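

In this assay, the exchange of the whole aromatic ring on the saturated ring carbon, 5-methylfuran-2-yl in place of 4-nitrophenyl, gives no change at the digits printed from compound 3 to compound 4 (within the scatter), so this position tolerates a five-membered aromatic ring with one hetero atom without leaving the level of compound 3. The same group in place of phenyl gives a number 10 percentage points lower from compound 1 to compound 4 (within the scatter), while in place of 4-methoxyphenyl it gives a number 90 percentage points lower from compound 2 to compound 4 (beyond the scatter), so among the four groups shown on this carbon, only 4-methoxyphenyl stands apart, and the three others cannot be told from one another on this read-out. No measured property of these compounds bears on why 4-methoxyphenyl alone separates from the others.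

The compounds shown leave open whether the high number belongs to the methoxy group itself or would also appear with an ethoxy, a hydroxy or a dimethylamino group on the same phenyl ring. They also leave open whether a methoxy group on the furan ring, in place of the methyl group of compound 4, would carry the same effect over to the five-membered ring.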